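This account rests on a few compounds, and the source may have more. Where it says the series, first, only, none or still open, it means among the compounds named here.

In a functional assay on MCF7 cells (Homo sapiens) for inhibition, read by sulforhodamine B assay, with a stated time of 24 h (on this read-out higher numbers stand for weaker inhibition of growth and lower numbers for stronger inhibition of growth), compound 1 `CC1=C(C(=O)Nc2ccccc2)C(c2cn(-c3ccccc3)nc2-c2ccccc2)NC(=O)N1` gives 80600 nM, compound 2 `CC1=C(C(=O)Nc2ccccc2)C(c2cn(-c3ccccc3)nc2-c2ccccc2)NC(=S)N1` gives 88200 nM and compound 3 `CC1=C(C(=O)Nc2ccc(C)cc2)C(c2cn(-c3ccccc3)nc2-c2ccccc2)NC(=S)N1` gives 56100 nM. The number for compound 3 is the lowest of the three shown, yet its gaps to compound 1 and to compound 2 both lie within the scatter. Compound 4 `CC1=C(C(=O)Nc2ccc(Cl)cc2)C(c2cn(-c3ccccc3)nc2-c2ccccc2)NC(=S)N1` differs from compound 3 by chloro in place of methyl on an aromatic carbon. Among the compounds with values here, no measured step exchanges one group for another at that place; the single measured step, a 1.6-fold lower number from compound 2 to compound 3 (0.20 log units; within the scatter), is the only guide, and it stayed within the scatter. Compound 4 is therefore expected to show no step beyond the scatter in this assay, a 1.1-fold lower number from compound 3 to compound 4 (0.05 log units; within the scatter). The estimate for compound 4 is 50000 nM, with a range from 22000 nM to 110000 nM.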

Compound 4, concentration for 50% growth inhibition: 34700 nM
The estimate for compound 4 lay 1.4-fold (0.16 log units) above the measured number, and the stated range covers the measured number.
By their numbers in this assay, from the lowest: compounds 4, 3, 1 and 2 (each within the scatter of the next, the first and the last beyond it).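

In this assay, the place para to a large group on the phenyl ring of the carbamoyl group gives its first step beyond the scatter: chloro in place of hydrogen yields a 2.5-fold lower number from compound 2 to compound 4 (0.41 log units; beyond the scatter), a modest step. Chloro in place of methyl yields a 1.6-fold lower number from compound 3 to compound 4 (0.21 log units; within the scatter), which stays within the scatter, so these two groups are not separated here. Nothing at hand bears on the reason for the chloro step.

Open, going by these compounds, is whether a methoxy group, an amine or a carboxylic acid at this place would shift the number further. Also open, on these data alone, is whether chloro acts alike on the carbonyl core of compound 1.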